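Removing both methoxy groups: from compound 3 to compound 4

This account rests on a few compounds, and the source may have more. Where it says the series, first, only, none or still open, it means among the compounds named here.

Compound 1 `Cc1nc(-c2ccc(Cl)cc2)sc1C(=O)CSc1nc(-c2ccccc2)c(C#N)c(=O)[nH]1`: 88.9%
Compound 2 `COc1ccc(-c2nc(C)c(C(=O)CSc3nc(-c4cccc(OC)c4)c(C#N)c(=O)[nH]3)s2)cc1`: 71.3%
Compound 3 `COc1ccc(-c2nc(C)c(C(=O)CSc3nc(-c4ccc(OC)c(OC)c4)c(C#N)c(=O)[nH]3)s2)cc1`: 81.2%

In a functional assay on U-87MG ATCC cells for antiproliferative activity against U-87 MG (Homo sapiens), read by MTT assay, with a stated time of 48 h, tested at 5 uM (a lower number here means a stronger effect, a higher number a weaker effect of the compound at the concentration tested), compound 3 gives 81.2%, the second highest of the three numbers, within the scatter of both compound 1 and compound 2. The new compound 4 `COc1ccc(-c2nc(C)c(C(=O)CSc3nc(-c4ccccc4)c(C#N)c(=O)[nH]3)s2)cc1` differs from compound 3 by phenyl in place of 3,4-dimethoxyphenyl on an aromatic carbon. Going by the values given here, the one measured step that bears on this change is a number 9.9 percentage points higher from compound 2 to compound 3 (within the scatter), which adds a single methoxy group and stays within the scatter. Compound 1, with the same phenyl group but a different group on the shared core, gives 88.9%. A step of no more than the scatter is therefore expected for a number 1.2 percentage points lower from compound 3 to compound 4 (within the scatter), in no clear direction. Compound 4 is estimated at 80%, with a range from 66% to 94%.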

Compound 4, a percentage reported as activity, at one concentration (the size of the read-out at that concentration, not a potency): 99%
Beside the measured number, compound 4's estimate is 19 percentage points below it, outside the stated range (above it).
By their numbers in this assay, from the lowest: compounds 2, 3 and 1 (each within the scatter of the next, the first and the last beyond it); then compound 4.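

In this assay, losing the methoxy groups from this position now has a visible cost: a number 17.8 percentage points higher from compound 3 to compound 4 (beyond the scatter) and a number 27.7 percentage points higher from compound 2 to compound 4 (beyond the scatter) both lie beyond the scatter towards a weaker effect, whereas the step between the two methoxy-bearing compounds stayed within it. Away from this position, a number 10.1 percentage points higher from compound 1 to compound 4 (beyond the scatter), with methoxy in place of chloro, also goes towards a weaker effect. Nothing available explains these steps. The compounds shown leave open whether a hydroxyl group or an amine on this phenyl would lower the number as methoxy does.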